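The source may hold more compounds than are shown below. What is called first, only, known or untested is meant among the compounds shown, and "the series" means these compounds.

Measured in an ADME assay on C8166 cells (Homo sapiens) for cytotoxicity, read by colorimetric assay and MTT assay; a higher number here means that more compound is tolerated, a lower number that less compound is tolerated:
compound 1 `Cc1cc(S(N)(=O)=O)ccc1NC(=O)COc1ccc2cc(Br)ccc2c1C(=O)c1ccccc1` gives 29200 nM;
compound 2 `Cc1cccc(C(=O)c2c(OCC(=O)Nc3ccc(S(N)(=O)=O)cc3C)ccc3cc(Br)ccc23)c1` gives 6800 nM;
compound 3 `Cc1cc(S(N)(=O)=O)ccc1NC(=O)COc1ccc2cc(Br)ccc2c1C(=O)c1cccc(Cl)c1` gives 6800 nM.

Compound 3 sits level with compound 2 at the digits given; together they are the lowest of the three numbers, with compound 1 the furthest away: a 4.3-fold lower number from compound 1 to compound 3 (0.63 log units; beyond the scatter). Compound 4 `Cc1cc(S(N)(=O)=O)ccc1NC(=O)COc1ccc2cc(Br)ccc2c1C(=O)c1cccc(F)c1` differs from compound 3 by fluoro in place of chloro on an aromatic carbon. Within the data shown here, two measured steps bear on this position. The step of no change at the digits printed from compound 2 to compound 3 (within the scatter) shows that swapping one substituent for another there left the number unchanged within the scatter, while a 4.3-fold lower number from compound 1 to compound 3 (0.63 log units; beyond the scatter) shows that removing the substituent altogether raised it. A value for compound 4 between these two readings is expected, somewhat above compound 3 but possibly within the scatter: a 1.8-fold higher number from compound 3 to compound 4 (0.25 log units; within the scatter). Compound 4 is estimated at 12000 nM, range 5000 nM to 30000 nM.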

Compound 4, half-maximal cytotoxic concentration: 31000 nM
The estimate for compound 4 lay 2.6-fold (0.41 log units) below the measured number; the whole stated range lies below it.
By their numbers in this assay, from the lowest: compounds 2 and 3 (each within the scatter of the next); then compounds 1 and 4 (each within the scatter of the next).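

In this assay, a substituent at this position does not by itself lower the number: fluoro separates from chloro (a 4.6-fold higher number from compound 3 to compound 4 (0.66 log units; beyond the scatter)) and from methyl (a 4.6-fold higher number from compound 2 to compound 4 (0.66 log units; beyond the scatter)). Fluoro instead stays with hydrogen (a 1.1-fold higher number from compound 1 to compound 4 (0.03 log units; within the scatter)), so the earlier drop holds for chloro and methyl but not for every replacement of hydrogen. No available evidence accounts for this split.

Where a methoxy, an amine or a carboxylic acid would fall at this position remains open. So does whether the split between fluoro and chloro holds elsewhere on this phenyl ring.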